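The source may hold more compounds than are shown below. What is called first, only, known or untested is meant among the compounds shown, and "the series" means these compounds.

Compound 1 `O=C1O[C@H]([C@@H](O)Cn2cc(-c3ccc(Br)cc3)nn2)C(OCc2ccccc2)=C1OCc1ccccc1`: in a functional assay on HCT-116 cells (Homo sapiens) for antiproliferative activity, read by MTT assay, with a stated time of 72 h (a lower number here means a stronger inhibitor, a higher number a weaker inhibitor), compound 1 gives 9420 nM.
Compound 2 `Cc1ccc(-c2cn(C/C=C3\OC(=O)C(OCc4ccccc4)=C3OCc3ccccc3)nn2)cc1`: compound 2 gives only a limit, > 100000 nM.
Compound 3 `O=C1O/C(=C\Cn2cc(-c3cc(F)cc(F)c3)nn2)C(OCc2ccccc2)=C1OCc1ccccc1`: compound 3 gives only a limit, > 100000 nM.

Among the measured compounds shown here, compound 1 thus stands as the only plain number among the three; the other two sit at the limit of > 100000 nM in this assay, at which 2 of the 3 values shown sit, and so the step that the two limits leave unreadable from compound 2 to compound 3 cannot be read. Compound 4 `O=C1O[C@H]([C@@H](O)Cn2cc(-c3cccc(O)c3)nn2)C(OCc2ccccc2)=C1OCc1ccccc1` differs from compound 1 in one place: 3-hydroxyphenyl in place of 4-bromophenyl on an aromatic carbon. For the measured compounds named here, none of the measured steps touches this exchange, and the one step recorded gives no size, so no direction can be taken from them. The expected step is a 1.1-fold higher number from compound 1 to compound 4 (0.03 log units; within the scatter), a change within the usual scatter. Compound 4 is therefore estimated at 10000 nM, with a range from 3000 nM to 40000 nM.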

Compound 4, half-maximal inhibitory concentration: 42900 nM
Beside the measured number, compound 4's estimate is 4.3-fold (0.63 log units) below it; the whole stated range lies below it.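

In this assay, among the compounds shown here, this is the first step at this position whose size can be read, and swapping the aryl group on the five-membered aromatic ring gives a 4.6-fold higher number from compound 1 to compound 4 (0.66 log units; beyond the scatter). The group entering here adds a hydrogen-bond donor and a hydrogen-bond acceptor, and compound 4 still gives a plain number rather than a limit. Nothing shown gives a cause for this weakening. From the compounds shown here alone, the step changes both the substituent and its ring position, so their shares stay open. The 3-bromophenyl and 4-hydroxyphenyl groups would pull these apart, and a 3-aminophenyl group would test another substituent.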